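Cytotoxicity notes: cyclobutyl analogue of the pentyl compound

The source may report more compounds than this note shows. Statements on the series, on what has been measured and on what is new or still open speak of the compounds shown alone.

Compound 1 `CCNc1cc(Oc2c(OC)cc3cc(C#N)ccc3c2OC)nc(Nc2ccc(C#N)cc2)n1` gives a limit in an ADME assay on MT4 cells (Homo sapiens) for cytotoxicity, read by MTT assay, with a stated time of 5 days (on this read-out higher numbers stand for lower toxicity in this test and lower numbers for higher toxicity in this test), > 125000 nM.
Compound 2 `CCCCCNc1cc(Oc2c(OC)cc3cc(C#N)ccc3c2OC)nc(Nc2ccc(C#N)cc2)n1` gives a limit in this assay, > 125000 nM.
Compound 3 `CCCC(C)Nc1cc(Oc2c(OC)cc3cc(C#N)ccc3c2OC)nc(Nc2ccc(C#N)cc2)n1` gives a limit in this assay, > 125000 nM.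

Compound 2 stands only at a limit in this assay, not at a number; (the limit of > 125000 nM in this assay, at which 3 of the 3 values shown sit). The steps among the measured compounds, a step that the two limits leave unreadable from compound 1 to compound 2, a step that the two limits leave unreadable from compound 1 to compound 3 and a step that the two limits leave unreadable from compound 2 to compound 3, are therefore unreadable in size and direction. Compound 4 `COc1cc2cc(C#N)ccc2c(OC)c1Oc1cc(NC2CCC2)nc(Nc2ccc(C#N)cc2)n1` differs from compound 2 by cyclobutyl in place of pentyl on a nitrogen on an aromatic ring. Among the measured compounds shown here, no measured step gives a readable size for such a change, and no value here is a number. Compound 4 is expected to sit again at the limit, estimated at 125000 nM, range 60000 nM to 250000 nM. The step this estimate means is a number no higher from compound 2 to compound 4 (the limit leaves the size open), expected to be no more than scatter.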

Compound 4, half-maximal cytotoxic concentration: > 125000 nM
Compound 4: no number, only a limit (the forecaster's own chance of this, stated with the estimate: 85%); the middle value lies on the limit itself.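

No step linking compound 4 to compound 1, compound 2 or compound 3 can be read in this assay, as all four values are limits, not numbers: the limit of > 125000 nM in this assay, at which 4 of the 4 values shown sit.

The compounds shown leave open how far each lies past that limit, and whether the groups on the nitrogen make any difference to cytotoxicity.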